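The source may report more compounds than this note shows. Statements on the series, on what has been measured and on what is new or still open speak of the compounds shown alone.

Series notes. In an in vitro functional assay on HEK285-7 cells for antagonist activity at prostaglandin D2 receptor 2 (Homo sapiens), read by BRET and beta-arrestin recruitment (on this read-out higher numbers stand for larger maximal responses and lower numbers for smaller maximal responses), compound 1 `O=C(O)Cc1sc(C(c2ccccc2)c2ccccc2)nc1-c1ccc(F)cc1` reaches 80%, compound 3 `O=C(O)Cc1sc(CSc2ccccc2)nc1-c1ccc(Cl)cc1` reaches 50%, and compound 2 `N#Cc1ccc(-c2nc(C(c3ccc(F)cc3)c3ccc(F)cc3)sc2CC(=O)O)cc1` reaches 30%. Compound 2 stands lowest of the three numbers; compound 3 lies nearest and compound 1 furthest, both gaps beyond the scatter. Compound 4 `O=C(O)Cc1sc(C(c2ccc(F)cc2)c2ccc(F)cc2)nc1-c1ccnc(O)c1` is not yet measured. It differs from compound 2 by one change on the shared core, (2-hydroxypyridin-4-yl in place of 4-cyanophenyl on an aromatic carbon). Among the measured compounds shown here, no step between measured compounds covers this change, so its size in this assay can only be judged from the spread among compounds 1, 2 and 3, which carry different groups at this aromatic carbon. A moderate upward step is expected, though a change within the scatter cannot be excluded. The expected step is a number 15 percentage points higher from compound 2 to compound 4 (beyond the scatter). Compound 4 is estimated at 45%, with a range from 20% to 75%.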

Compound 4, largest response reached (reported as efficacy), in percent of the reference or control that the assay uses: 60%
Compound 4: the middle estimate sits 15 percentage points below what was measured; low and high end bracket the measured number.
By their numbers in this assay, from the lowest: compound 2; then compounds 3 and 4 (each within the scatter of the next); then compound 1.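

In this assay, the aromatic carbon next to the ring nitrogen responds to the group it carries: 2-hydroxypyridin-4-yl in place of 4-cyanophenyl gives a number 30 percentage points higher from compound 2 to compound 4 (beyond the scatter) with the rest of the structure unchanged. Among the compounds shown here, this is the first step that isolates this position, and it lies beyond the scatter. Nothing available on these compounds explains the step.

Open, on these data alone, is whether the ring nitrogen, the hydroxyl or both account for the step. An unsubstituted pyridin-4-yl or a 2-aminopyridin-4-yl on the same carbon would separate these.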